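Hydroxy to carboxy on the quinoline-type core: antiproliferative series

The source may hold more compounds than are shown below. What is called first, only, known or untested is meant among the compounds shown, and "the series" means these compounds.

Of the compounds shown here, three have been measured in a functional assay on A-375 cells (Homo sapiens) for antiproliferative activity, read by MTT assay, with a stated time of 24 h; on this read-out higher numbers stand for weaker inhibition and lower numbers for stronger inhibition. Compound 1 `CCc1ccc2nc(C(=O)Nc3c(F)cc(-c4cccc(F)c4)cc3F)c(C)c(O)c2c1` gives 8130 nM, the lowest number of the three. Compound 3 `CCc1ccc2nc(C(=O)Nc3c(F)cc(-c4cccc(F)c4)cc3F)c(C)c(C(=O)O)c2c1` carries the same core and the same aryl amide part but differs in one place: carboxy in place of hydroxy on an aromatic carbon. This change gives a 7.1-fold higher number from compound 1 to compound 3 (0.85 log units; beyond the scatter), so compound 3 reaches 57800 nM. Compound 2 `COc1ccc2nc(C(=O)Nc3ccc(-c4ccccc4)cc3)c(C)c(O)c2c1` has a methoxy group in place of the ethyl group on the core and a different aryl amide part; the difference between the two cores is not broken down here. In this assay compound 2 gives 50600 nM, which sits within the scatter of compound 3 and well beyond the scatter of compound 1.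

Compound 4 `COc1ccc2nc(C(=O)Nc3ccc(-c4ccccc4)cc3)c(C)c(C(=O)O)c2c1` has not yet been measured. It stands to compound 2 as compound 3 stands to compound 1: carboxy in place of hydroxy on an aromatic carbon. The place of the change is the same word for word in both pairs, so the change is the same one, made a second time on a core that differs in its other groups. For the measured compounds named here, only one measured instance of the change exists, in a pair whose aryl amide part is not that of compound 2, so the transfer is uncertain. The expectation is nonetheless a step of a 4.3-fold higher number from compound 2 to compound 4 (0.64 log units; beyond the scatter) from compound 2 to compound 4, resting on the step of a 7.1-fold higher number from compound 1 to compound 3 (0.85 log units; beyond the scatter). Because compound 2 already gives 50600 nM, a step of that size is expected to leave compound 4 with a high number, that is, weak inhibition on this read-out. Compound 4 is estimated at 220000 nM, with a range from 60000 nM to 700000 nM.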

Compound 4, half-maximal inhibitory concentration: > 100000 nM
Compound 4 gave a limit, no number; the forecaster's own chance of this, stated with the estimate: 35%; the middle value is on the limit's open side.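

In this assay, compound 4 gives > 100000 nM, which is a limit of the assay and not a number. Carboxy in place of hydroxy on an aromatic carbon therefore gives an at least 1.9-fold higher number from compound 2 to compound 4 (0.29 log units; that floor lies within the scatter), so on this core the result agrees in direction with the earlier pair, but its floor alone does not establish a shift beyond the usual scatter. Whether the size of the step carries over from one core to the other cannot be read from this pair, and a single limit is no basis for calling the change additive or core-dependent: the same change on two cores in this assay, a 7.1-fold higher number (0.85 log units; beyond the scatter) from compound 1 to compound 3 and an at least 1.9-fold higher number (0.29 log units; that floor lies within the scatter) from compound 2 to compound 4; the limit leaves it open whether they differ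

From the compounds shown here alone, the two pairs differ in both the group on the core, ethyl or methoxy, and the aryl amide part, so the contribution of each to any difference in the step remains open, as does the true size of the step on the core of compound 2. Also open, going by these compounds, is how an amine or a primary carboxamide on the same aromatic carbon would compare with hydroxy and carboxy on either core.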